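The source may report more compounds than this note shows. Statements on the series, on what has been measured and on what is new or still open speak of the compounds shown alone.

Compound 1, `COc1cc2c(c(O)c1C(=O)/C=C/c1ccc(OC(=O)C3CCC3)cc1)CCC(C)(C)O2`, is the starting point. In an assay on HEK293T cells for inhibition of nuclear factor NF-kappa-B complex (Homo sapiens), read by a luciferase reporter (a higher number here means a weaker inhibitor, a lower number a stronger inhibitor), compound 1 gives > 30000 nM, which is a limit of the assay and not a measured number. Compound 2, `COc1cc2c(c(O)c1C(=O)/C=C/c1ccc(OC(=O)c3ccc(OC(F)(F)F)cc3)cc1)CCC(C)(C)O2`, carries a different group on the same carbonyl carbon. In this assay compound 2 gives > 30000 nM, again a limit rather than a number. Between them lies a step that the two limits leave unreadable from compound 1 to compound 2, because of the limit of > 30000 nM in this assay, at which 2 of the 2 values shown sit. Compound 3, `C=CC(=O)Oc1ccc(/C=C/C(=O)c2c(OC)cc3c(c2O)CCC(C)(C)O3)cc1`, has not yet been measured; it differs from compound 1 in this way: vinyl in place of cyclobutyl on a carbonyl carbon. Among the compounds with values here, no measured step involves a vinyl group, and the only measured step, from cyclobutyl to 4-(trifluoromethoxy)phenyl, gave no readable size. With both measured values sitting at the limit, no direction can be drawn from them. Compound 3 is therefore expected to sit near the same limit, so the expected step that the limit leaves unreadable from compound 1 to compound 3 is about none beyond the scatter. The estimate for compound 3 in this assay is 35000 nM, with a range from 10000 nM to 100000 nM, and a limit rather than a number is the more likely outcome.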

Compound 3, half-maximal inhibitory concentration: 8990 nM
For compound 3 the middle estimate is 3.9-fold (0.59 log units) above the measured one; measured number below the stated range.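

Vinyl is the first group on this carbonyl carbon to give a number rather than a limit: in this assay, compound 3 gives 8990 nM, so what sits at this position can change the read-out. Replacing cyclobutyl with vinyl gives an at least 3.3-fold lower number from compound 1 to compound 3 (0.52 log units; beyond the scatter), and replacing 4-(trifluoromethoxy)phenyl with vinyl gives an at least 3.3-fold lower number from compound 2 to compound 3 (0.52 log units; beyond the scatter). Both sizes are minimum values, and the full size of each step stays hidden: the limit of > 30000 nM in this assay, at which 2 of the 3 values shown sit.

The compounds shown leave open whether the lower number goes with the double bond of vinyl, with its smaller count of heavy atoms, or with the absence of a ring, as vinyl differs from both cyclobutyl and 4-(trifluoromethoxy)phenyl in all three of these ways. An ethyl group on the same carbonyl carbon would test the double bond directly, while a longer chain ending in a double bond, such as allyl, would show whether the double bond still goes with a measurable number when it sits further from the carbonyl carbon.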